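Swapping an Acid-Bearing Arm for a Benzimidazole Arm

A few compounds are considered here, and "the series" means these few. Any claim that something is new, unique, unknown or untested is made for them only; others in the source may bear on it.

Measured so far:
Compound 1 `Cc1cc(C(=O)O)ccc1C(C)N1CCC[C@H](O[C@H](CO)c2cc(Cl)cc(Cl)c2)[C@@H]1c1ccccc1`: 18000 nM
Compound 2 `Cc1cc(C(=O)O)ccc1CN1CCC[C@H](O[C@H](CO)c2cc(Cl)cc(Cl)c2)[C@@H]1c1ccc(F)cc1`: 18000 nM
Compound 3 `Cc1cc(C(=O)O)ccc1CN1CCC[C@H](O[C@H](CF)c2cc(Cl)cc(Cl)c2)[C@@H]1c1ccccc1`: 9100 nM

All three compounds were tested in an assay on isolated protein for activation of cGMP-dependent protein kinase 1 (Homo sapiens), read by ADP-Glo, with stated times of 30 min and 2 h, in the presence of a further agent that is not named here; on this read-out higher numbers stand for an effect only at larger amounts of compound and lower numbers for an effect already at smaller amounts. Compound 1 gives 18000 nM, the same number at the digits shown as compound 2, and together these two are the highest of the three numbers. Compound 3 gives 9100 nM, which sits within the usual scatter of the number for compound 1. So compound 1 stands at the weak end of this small set, yet none of its gaps to the other two compounds lies beyond the scatter, and no ordering among them can be claimed.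

Compound 4 `OC[C@@H](O[C@H]1CCCN(Cc2nc3ccccc3[nH]2)[C@H]1c1ccccc1)c1cc(Cl)cc(Cl)c1` is the untested candidate. Compared with compound 1 the change is: a group of 10 heavy atoms (8 carbon, 2 nitrogen; one five-membered aromatic ring with 2 hetero atoms, one six-membered aromatic ring of carbon only) in place of a group of 12 heavy atoms (10 carbon, 2 oxygen; one six-membered aromatic ring of carbon only), on an amine nitrogen in a ring. The group that leaves carries a carboxylic acid; the group that enters is the (1H-benzimidazol-2-yl)methyl unit, and the swap happens on an amine nitrogen in a ring of the shared core.

Among the compounds with values here, no pair of measured compounds shows a step of this kind, so the size of the step is not anchored by data. The expectation is that the step of a 1.2-fold lower number from compound 1 to compound 4 (0.08 log units; within the scatter) stays within the scatter, with a wide range around it. For compound 4 the estimate in this assay is 15000 nM, between 4000 nM and 60000 nM.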

Compound 4, half-maximal effective concentration: 4700 nM
For compound 4 the middle estimate is 3.2-fold (0.50 log units) above the measured one, within the range that was stated.
By their numbers in this assay, from the lowest: compounds 4, 3, 1 and 2 (each within the scatter of the next, the first and the last beyond it).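

Putting the (1H-benzimidazol-2-yl)methyl group on the amine nitrogen in place of the arm carrying the carboxylic acid gives, in this assay, a 3.8-fold lower number from compound 1 to compound 4 (0.58 log units; beyond the scatter), which is a modest change but the first one in this set that can be read with confidence. It shows that this position accepts a quite different group, and that a carboxylic acid on the arm is not required for an effect in this assay. The two groups have matching counts of hydrogen-bond donors and acceptors, so those counts do not distinguish them, and nothing measured here accounts for the lower number.

The whole arm changes in one step, so the compounds shown cannot separate the loss of the carboxylic acid from the arrival of the five-membered ring with its two nitrogens. From the compounds shown here alone, an unsubstituted benzyl group or an imidazol-2-ylmethyl group on the same nitrogen would help to pull these apart, and it remains open whether the same swap would give a similar step on other members.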